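Furan for tolyl on the shared core

The source may report more compounds than this note shows. Statements on the series, on what has been measured and on what is new or still open speak of the compounds shown alone.

Compound 2 `COc1nc(-c2nc3ccccc3n2C)cc(-c2ccc(C)cc2)c1C#N` gives 295000 nM in a functional assay on aorta (Rattus norvegicus, strain Wister) (on this read-out lower numbers stand for stronger inhibition and higher numbers for weaker inhibition), the lowest of the three numbers but within the scatter of compound 1 `CCOc1nc(-c2nc3ccccc3n2C)cc(-c2ccc(F)cc2)c1C#N` with 362000 nM and of compound 3 `CCOc1nc(-c2nc3ccccc3n2C)cc(-c2ccc(C)cc2)c1C#N` with 400000 nM. Compound 4 `COc1nc(-c2nc3ccccc3n2C)cc(-c2ccc(C)o2)c1C#N` differs from compound 2 by 5-methylfuran-2-yl in place of 4-methylphenyl on an aromatic carbon. For the measured compounds named here, no measured step exchanges this ring for another; the nearest is a 1.1-fold higher number from compound 1 to compound 3 (0.04 log units; within the scatter), which altered the 4-methylphenyl group and stayed within the scatter, and a 1.4-fold higher number from compound 2 to compound 3 (0.13 log units; within the scatter) at the methoxy side also stayed within the scatter. All three numbers sit close together, so no step beyond the scatter is expected in this assay in either direction. For compound 4 the expected value is 300000 nM, with a range from 100000 nM to 900000 nM. The expected step is a 1.0-fold higher number from compound 2 to compound 4 (0.01 log units; within the scatter).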

Compound 4, half-maximal inhibitory concentration: 283000 nM
Compound 4: middle estimate off by 1.1-fold (0.03 log units), on the high side; measured number inside the range.
By their numbers in this assay, from the lowest: compounds 4, 2, 1 and 3 (each within the scatter of the next).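

In this assay, 5-methylfuran-2-yl in place of 4-methylphenyl gives a 1.0-fold lower number from compound 2 to compound 4 (0.02 log units; within the scatter). Unlike the earlier steps, this one exchanges the whole ring, and a five-membered aromatic ring with 1 hetero atom on this aromatic carbon, ortho to a cyano group, stays within the scatter of the six-membered carbon ring. Nothing available explains this tolerance.

From the compounds shown here alone, whether any group at this position moves the number remains open. A phenyl ring carrying an amine or a carboxylic acid would probe it further.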